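This account rests on a few compounds, and the source may have more. Where it says the series, first, only, none or still open, it means among the compounds named here.

Measured compounds:
- compound 1, `CC1SC(c2cccc(C(=O)NCCCCc3ccccc3)c2)N(c2ccc(C3CC3)cc2)C1=O`: 10000 nM
- compound 2, `COc1ccccc1N1C(=O)C(C)SC1c1cccc(C(=O)NCCCCc2ccccc2)c1`: 20000 nM
- compound 3, `COc1ccc(F)cc1N1C(=O)CSC1c1cccc(C(=O)NCCCCn2cccn2)c1`: 50000 nM

In a physicochemical assay for solubility, read by turbidimetry, measured as kinetic solubility, at pH 6.8 (on this read-out higher numbers stand for higher solubility and lower numbers for lower solubility), compound 3 gives the highest of the three numbers. Its nearest neighbour is compound 2, which gives 20000 nM, a gap beyond the scatter, and compound 1, with 10000 nM, lies further off. Among the compounds with values here, the only step in which two measured compounds differ in one place is a 2.0-fold higher number from compound 1 to compound 2 (0.30 log units; within the scatter), a swap of one aryl group on the same amide-type nitrogen in a ring.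

Compound 4, `O=C(NCCCCn1cccn1)c1cccc(C2SCC(=O)N2c2ccccn2)c1`, is the next compound for this assay. It departs from compound 3 in one place: pyridin-2-yl in place of 5-fluoro-2-methoxyphenyl on an amide-type nitrogen in a ring. The measured step from compound 1 to compound 2 is the only one that bears on this change, since it also exchanges the aryl group on the amide-type nitrogen in a ring, and it stayed within the scatter. Neither pyridin-2-yl nor the amide-type nitrogen carrying it has been measured in this series, so the step to compound 4 is expected to be small, if anything upward from compound 3. For compound 4 the expected value in this assay is 70000 nM, with a range of 30000 nM to 160000 nM, meaning an expected step of a 1.4-fold higher number from compound 3 to compound 4 (0.15 log units; within the scatter).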

Compound 4, solubility: 50000 nM
Compound 4: middle estimate off by 1.4-fold (0.15 log units), on the high side; the measured number falls inside the stated range.
By their numbers in this assay, from the lowest: compounds 1 and 2 (each within the scatter of the next); then compounds 3 and 4 (each within the scatter of the next).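

In this assay, the read-out shows no change at the digits printed from compound 3 to compound 4 (within the scatter) when pyridin-2-yl, with 6 heavy atoms and a ring hetero atom, stands in place of 5-fluoro-2-methoxyphenyl, with 9 heavy atoms and a carbon-only ring, on the amide-type nitrogen in a ring. Within the data shown here, this is the first measured case of a ring nitrogen in the aryl group at this position, and it joins a 2.0-fold higher number from compound 1 to compound 2 (0.30 log units; within the scatter) as a second aryl swap on this nitrogen within the scatter, although that earlier pair carries a different chain and a methyl group on the core, so the two steps share only the type of change. No measurement here explains why the number holds across this swap.

Still open, going by these compounds, is whether the flat result extends beyond aromatic rings on this nitrogen, for instance to pyridin-3-yl, a morpholine-bearing phenyl group or a phenyl group carrying a carboxylic acid. The part played by the pyrazolyl end of the butyl chain also stays unresolved, since compound 2 and compound 3 differ in more than one place and give no single-change comparison.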